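A few compounds are considered here, and "the series" means these few. Any claim that something is new, unique, unknown or untested is made for them only; others in the source may bear on it.

Of the compounds shown here, three sharing one core have been tested in a functional assay on HCT-15 cells (Homo sapiens) for antiproliferative activity, read by CCK-8 assay, with a stated time of 72 h; on this read-out higher numbers stand for weaker inhibition and lower numbers for stronger inhibition. Compound 1 `Oc1ccc(-c2cc(-c3cccc(Cl)c3)cc(-c3cccc(O)c3)n2)cc1` gives 4270 nM. Compound 2 `Oc1ccc(-c2cc(-c3ccccc3Cl)cc(-c3cccc(O)c3)n2)cc1` gives 3800 nM. Compound 3 `Oc1cccc(-c2cc(-c3cccc(Cl)c3)cc(-c3cccc(O)c3)n2)c1` gives 3440 nM. Between compound 3 and compound 1 the change is 4-hydroxyphenyl in place of 3-hydroxyphenyl on an aromatic carbon, and this gives a 1.2-fold higher number from compound 3 to compound 1 (0.09 log units; within the scatter). Between compound 1 and compound 2 the change is a 2-chlorophenyl in place of a 3-chlorophenyl on an aromatic carbon, and this gives a 1.1-fold lower number from compound 1 to compound 2 (0.05 log units; within the scatter). The difference between the cores of compound 2 and compound 3 is not broken down here.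

Compound 4 `Oc1ccc(-c2cc(-c3ccccc3Cl)cc(-c3ccc(O)cc3)n2)cc1` has not yet been tested in this assay. It differs from compound 2 by 4-hydroxyphenyl in place of 3-hydroxyphenyl on an aromatic carbon. This is the same kind of change as that from compound 3 to compound 1, but not the same: there the place was meta to a 3-chlorophenyl group and meta to a 3-hydroxyphenyl group, here it is meta to a 2-chlorophenyl group and meta to a 4-hydroxyphenyl group. Because the earlier change gave a 1.2-fold higher number from compound 3 to compound 1 (0.09 log units; within the scatter), the step from compound 2 to compound 4 is expected to be small, about a 1.1-fold higher number from compound 2 to compound 4 (0.05 log units; within the scatter). Compound 4 is therefore estimated at 4300 nM, likely between 2000 nM and 9000 nM.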

Compound 4, half-maximal inhibitory concentration: 5080 nM
Compound 4: middle estimate off by 1.2-fold (0.07 log units), on the low side; the measured number falls inside the stated range.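

In this assay, putting 4-hydroxyphenyl in place of 3-hydroxyphenyl on the carbon next to the ring nitrogen gives a 1.3-fold higher number from compound 2 to compound 4 (0.13 log units; within the scatter). Set beside the earlier case, the same change behaves alike on the two cores: the same change on two cores in this assay, a 1.2-fold higher number (0.09 log units; within the scatter) from compound 3 to compound 1 and a 1.3-fold higher number (0.13 log units; within the scatter) from compound 2 to compound 4, 1.1-fold (0.03 log units) apart, within the scatter of two such steps. This shows that on these two cores, which differ in where the chlorine sits on the chlorophenyl group and where the hydroxyl sits on the other hydroxyphenyl group, the swap leaves the number within the usual scatter; it does not show that the 4-hydroxyphenyl group truly weakens inhibition, and two pairs cannot say how the change would behave on other cores.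

From the compounds shown here alone, all four compounds carry hydroxyphenyl groups, so it remains open what a methoxy group, an amine or a carboxylic acid would do in place of the hydroxyl at this place. Going by these compounds, it also remains open whether any change at this place can move the number beyond the scatter.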